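A few compounds are considered here, and "the series" means these few. Any claim that something is new, unique, unknown or untested is made for them only; others in the source may bear on it.

Compound 3 `C=CC1=C(C(=O)Nc2ccccc2)C(c2ccc(F)cc2)OC1` is one of three amides built on a shared core, the others being compound 1 `C=CC1=C(C(=O)Nc2ccccc2OC)C(c2ccc(F)cc2)OC1` and compound 2 `C=CC1=C(C(=O)NC(C)(C)C)C(c2ccc(F)cc2)OC1`. In a functional assay on HeLa cells (Homo sapiens) for cytotoxicity, read by MTT assay, with a stated time of 24 h (on this read-out higher numbers stand for weaker inhibition and lower numbers for stronger inhibition), compound 3 reaches only a limit of the assay, recorded as > 100000 nM. Compound 1 likewise stands at a limit, recorded as > 100000 nM. Compound 2 also stands at a limit, recorded as > 100000 nM. The three steps between them, a step that the two limits leave unreadable from compound 1 to compound 2, a step that the two limits leave unreadable from compound 1 to compound 3 and a step that the two limits leave unreadable from compound 2 to compound 3, cannot be sized because the limit of > 100000 nM in this assay, at which 3 of the 3 values shown sit, holds every value shown. Compound 4 `C=CC1=C(C(=O)NC2CCCCC2)C(c2ccc(F)cc2)OC1` differs from compound 3 by cyclohexyl in place of phenyl on an amide-type nitrogen, an exchange of one six-membered ring for another on the amide nitrogen. Within the data shown here, no measured step bears a readable size on this change, so the three limits are all there is to go on. Compound 4 is therefore expected to sit near 100000 nM, with a range from 50000 nM to 300000 nM, most probably reported again as a limit. The step of a number no higher from compound 3 to compound 4 (the limit leaves the size open) is expected to be none beyond the scatter.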

Compound 4, half-maximal inhibitory concentration: > 100000 nM
Compound 4: no number, only a limit; the forecaster's own chance of this, stated with the estimate: 85%; the middle value lies on the limit itself.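

Among these compounds, no step to compound 4 from compound 1, compound 2 or compound 3 can be read, because compound 4 again gives only a limit: the limit of > 100000 nM in this assay, at which 4 of the 4 values shown sit. The compounds shown leave open whether any group on the amide nitrogen of the shared core changes the result in this assay.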